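The source may hold more compounds than are shown below. What is called first, only, known or untested is meant among the compounds shown, and "the series" means these compounds.

Measured so far in a physicochemical assay for solubility, using the shake flask method, in simulated intestinal fluid, measured as kinetic solubility, with a stated time of 2 h, at 25 degrees C, at pH 6.5; a lower number here means a less soluble compound, a higher number a more soluble compound:
- Compound 1 `CCOC(=O)c1nc(C)c2c(c1N)C(=O)N(Cc1ccccc1)C2=O`: < 5000 nM
- Compound 2 `Cc1noc(-c2nc(C)c3c(c2N)C(=O)N(CC2CCNCC2)C3=O)n1`: 160000 nM

Compound 1 reads < 5000 nM, which is a limit of the assay and not a number. Among the measured compounds shown here, compound 2 gives 160000 nM, the only true number available, so there is no series yet against which to rank it.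

Compound 3 `Cc1noc(-c2nc(C)c3c(c2N)C(=O)N(Cc2ccc(Br)cc2)C3=O)n1` has not been measured. It keeps the rest of compound 2 and changes one group: 4-bromophenyl in place of piperidin-4-yl on a saturated chain carbon bound to an amide-type nitrogen in a ring. In words, 4-bromophenyl takes the place of piperidin-4-yl on a saturated chain carbon bound to an amide-type nitrogen in a ring, so (piperidin-4-yl)methyl becomes 4-bromobenzyl.

For the measured compounds named here, no measured pair shows this change on its own, so the expectation is a judgement. A large downward step in this assay is expected, well beyond the usual scatter. Compound 3 is expected to lie near (the limit of < 5000 nM in this assay, at which 1 of the 2 values shown sits), and the assay may then report only a limit. The estimated step is a 40-fold lower number from compound 2 to compound 3 (1.60 log units; beyond the scatter). For compound 3 the estimate is 4000 nM, with an expected range of 1000 nM to 15000 nM.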

Compound 3, solubility: < 5000 nM
Compound 3 was reported as a limit; the forecaster's own chance of this, stated with the estimate: 65%; the middle value is on the limit's open side.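

Compound 2 and compound 3 differ only in the group on a saturated chain carbon bound to an amide-type nitrogen in a ring, so this pair gives the first direct view of that position in this assay and shows that the change matters: replacing piperidin-4-yl with 4-bromophenyl gives an at least 32-fold lower number from compound 2 to compound 3 (1.50 log units; beyond the scatter). The reading for compound 3 is < 5000 nM and this is a limit of the assay, not a number, so the printed step is a minimum and its full size cannot be read. The same limit now appears more than once in this small set: the limit of < 5000 nM in this assay, at which 2 of the 3 values shown sit.

The change swaps a non-aromatic ring holding a nitrogen for an aromatic carbon ring bearing bromine, so this single pair cannot separate the part played by the ring nitrogen, the aromatic ring and the bromine. Going by these compounds, it also remains open whether an unsubstituted phenyl or an open-chain amine such as 2-aminoethyl at this position would give a reading near that of compound 2 or one at the limit.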